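Swapping dimethylamino for pyrrolidin-1-yl in an antiproliferative series

A few compounds are considered here, and "the series" means these few. Any claim that something is new, unique, unknown or untested is made for them only; others in the source may bear on it.

In a functional assay on HT-29 cells (Homo sapiens) for antiproliferative activity, read by MTT assay, with a stated time of 24 h (a higher number here means a weaker inhibitor, a lower number a stronger inhibitor), compound 1 (`COc1cccc(/C=C/C(=O)c2ccc(OC)c3c2OC(C)(C)C=C3)c1`) gives > 10000 nM as a limit and not a number. Compound 2 (`COc1ccc(C(=O)/C=C/c2ccc(Br)cc2)c2c1C=CC(C)(C)O2`) gives > 10000 nM and that too is a limit. Among the measured compounds shown here, compound 3 (`COc1ccc(C(=O)/C=C/c2ccc(N(C)C)cc2)c2c1C=CC(C)(C)O2`) gives 1870 nM as the only true number so far. Both an at least 5.3-fold lower number from compound 1 to compound 3 (0.72 log units; beyond the scatter) and an at least 5.3-fold lower number from compound 2 to compound 3 (0.72 log units; beyond the scatter) lead to it. Compound 4 (`COc1ccc(C(=O)/C=C/c2ccc(N3CCCC3)cc2)c2c1C=CC(C)(C)O2`) differs in one place: pyrrolidin-1-yl in place of dimethylamino on an aromatic carbon with pyrrolidin-1-yl in place of dimethylamino on an aromatic carbon. The gain in an at least 5.3-fold lower number from compound 2 to compound 3 (0.72 log units; beyond the scatter) came with dimethylamino entering, and pyrrolidin-1-yl also carries a nitrogen, so little change is expected in this assay here. The expected change is a 1.1-fold lower number from compound 3 to compound 4 (0.04 log units; within the scatter) and so none beyond the scatter. Compound 4 is estimated at 1700 nM with 600 nM to 5500 nM as the expected range.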

Compound 4, half-maximal inhibitory concentration: 8360 nM
Estimate against measurement, compound 4: 4.9-fold (0.69 log units) below; measured number above the stated range.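

A nitrogen on this aromatic carbon is not enough to hold the activity seen with dimethylamino: pyrrolidin-1-yl in its place gives a 4.5-fold higher number from compound 3 to compound 4 (0.65 log units; beyond the scatter) in this assay. The two amines are therefore not interchangeable at this position. Set against bromo, pyrrolidin-1-yl gives only an at least 1.1-fold lower number from compound 2 to compound 4 (0.07 log units; that floor lies within the scatter), a floor fixed by a limit and not a measured gap: the limit of > 10000 nM in this assay, at which 2 of the 4 values shown sit. As far as these compounds go, what remains open is whether the loss follows the ring or the added carbons. Diethylamino, azetidin-1-yl and piperidin-1-yl at this carbon would separate the two.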